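The source may report more compounds than this note shows. Statements on the series, on what has been measured and on what is new or still open speak of the compounds shown alone.

In a functional assay on A549 cells (Homo sapiens) for cytotoxicity (a lower number here means a stronger inhibitor, a higher number a weaker inhibitor), compound 2 (`Cc1ccc(C2CNC(=O)N2S(=O)(=O)c2ccc3c(c2)CCC3)cc1`) gives 90300 nM as its half-maximal inhibitory concentration. Compound 1 (`O=C1NC(c2ccc(Cl)cc2)CN1S(=O)(=O)c1ccc2c(c1)CCC2`) gives 86300 nM and compound 3 (`Cc1ccc(C2CNC(=O)N2S(=O)(=O)c2ccccc2)cc1`) gives 157000 nM in this assay as well. All three numbers lie within the usual scatter of one another, so compound 2 cannot be ranked against either neighbour.

Compound 4 (`O=C1NCC(c2ccc(Br)cc2)N1S(=O)(=O)c1ccc2c(c1)CCC2`) has not been measured yet. It keeps the shared core of compound 2 and changes one group: bromo in place of methyl on an aromatic carbon with bromo in place of methyl on an aromatic carbon, so that 4-methylphenyl becomes 4-bromophenyl. Among the compounds with values here, no measured pair shows this exact swap, so the expectation has to lean on the overall spread. Compound 1 at 86300 nM and compound 3 at 157000 nM differ in structure from compound 2 yet stay within the scatter of it, and that suggests little movement from a swap this small.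

The expected 1.1-fold lower number from compound 2 to compound 4 (0.03 log units; within the scatter) is small, within the scatter, and has no firm direction. For compound 4 the estimated value is 85000 nM with an expected range from 45000 nM to 150000 nM in this assay when it is measured.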

Compound 4, half-maximal inhibitory concentration: > 237000 nM
Compound 4 was reported as a limit; the forecaster's own chance of this, stated with the estimate: 10%; at least 2.7-fold (0.44 log units) between middle value and limit.
By their numbers in this assay, from the lowest: compounds 1, 2 and 3 (each within the scatter of the next). At a limit, above all of these: compound 4.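

Within the data shown here, the swap of methyl for bromo is the first change at a single place that can be read in this set: on an aromatic carbon para to a large group, it gives an at least 2.6-fold higher number from compound 2 to compound 4 (0.41 log units; beyond the scatter) in this assay. Among these compounds, this shows that the position is sensitive to replacing one heavy atom with another, which the earlier compounds could not show, as none of them were a single change apart. Compound 4 stands only as a limit, not as a number: the limit of > 237000 nM in this assay, at which 1 of the 4 values shown sits.

The compounds shown leave open how a methoxy group, an amine or a carboxylic acid at the same place would read in this assay. They also give no reason for the rise, and they do not tell whether the same swap would read alike on the phenylsulfonyl form seen in compound 3.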